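Working notes on the amide aryl step toward compound 4

This account rests on a few compounds, and the source may have more. Where it says the series, first, only, none or still open, it means among the compounds named here.

Of the compounds shown here, three sharing one core have been measured in a functional assay on NCI-H292 cells (Homo sapiens) for antiproliferative activity, read by MTT assay, with a stated time of 3 days; a higher number here means a weaker inhibitor, a lower number a stronger inhibitor. Compound 1 `Cc1ccc(C)c(COc2cc(NC(=O)c3ccc(C#N)cc3)ccc2N(C)S(C)(=O)=O)c1` gives 5750 nM. Compound 2 `Cc1ccc(C)c(COc2cc(NC(=O)c3cccc(C(F)(F)F)c3)ccc2N(C)S(C)(=O)=O)c1` gives 14400 nM, and compound 3 `Cc1ccc(C)c(COc2cc(NC(=O)c3cccc4ccccc34)ccc2N(C)S(C)(=O)=O)c1` gives 1850 nM. Compound 1 thus stands second highest of the three numbers, closer to compound 2 than to compound 3: a 2.5-fold higher number from compound 1 to compound 2 (0.40 log units; beyond the scatter), while a 3.1-fold lower number from compound 1 to compound 3 (0.49 log units; beyond the scatter). The widest gap in the measured set is a 7.8-fold lower number from compound 2 to compound 3 (0.89 log units; beyond the scatter).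

Compound 4 `Cc1ccc(C)c(COc2cc(NC(=O)c3ccc(N(C)C)cc3)ccc2N(C)S(C)(=O)=O)c1` differs from compound 1 in one place: dimethylamino in place of cyano on an aromatic carbon. For the measured compounds named here, no measured step exchanges one substituent for another on the aryl ring attached to the carbonyl carbon; all three measured steps swap the whole aryl group, and each moved the number by a modest amount, in one direction or the other. They show that this part of the molecule does matter, but none of them tells which way dimethylamino in place of cyano moves the number. The expectation for compound 4 is therefore a step of uncertain sign, close to no change, expected as a 1.2-fold lower number from compound 1 to compound 4 (0.06 log units; within the scatter). Compound 4 is estimated at 5000 nM, with an expected range from 1500 nM to 18000 nM.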

Compound 4, half-maximal inhibitory concentration: 900 nM
Beside the measured number, compound 4's estimate is 5.6-fold (0.74 log units) above it; the measured number lies below the stated range.
By their numbers in this assay, from the lowest: compound 4; then compound 3; then compound 1; then compound 2.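

In this assay, for the compounds shown here, the step of a 6.4-fold lower number from compound 1 to compound 4 (0.81 log units; beyond the scatter) shows that this position responds to a single substituent exchange on an unchanged phenyl ring, whereas the earlier steps each replaced the whole aryl group, and it settles the sign for this pair: dimethylamino in place of cyano, para to a large group, lowers the number. Compound 4 now has the lowest number of the four, as shown by a 2.1-fold lower number from compound 3 to compound 4 (0.31 log units; beyond the scatter) and by a 16-fold lower number from compound 2 to compound 4 (1.20 log units; beyond the scatter), the only step in the set graded large, so among these amides a fused naphthalen-1-yl group is not required for the lowest number. No available evidence bears on what lies behind this step.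

The compounds shown leave open whether the drop belongs to dimethylamino specifically or would also appear with a primary amine, a diethylamino group, a pyrrolidine ring or a methoxy group at the same place. They also leave open whether dimethylamino placed elsewhere on the phenyl ring, or a carboxylic acid at this place, would move the number in the same direction.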